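Ketoester to ketoamide: heptylamino replacing butoxy in compound 1

A few compounds are considered here, and "the series" means these few. Any claim that something is new, unique, unknown or untested is made for them only; others in the source may bear on it.

Among the compounds with values here, compound 1 `CCCCOC(=O)C(=O)C(CC)NC(=O)C(CC(C)C)NC(=O)OCc1ccccc1` is one of three compounds measured in an assay on isolated protein (Oryctolagus cuniculus) for inhibition of Calpain-2 catalytic subunit (Homo sapiens), at pH 8.0 (a higher number here means a weaker inhibitor, a lower number a stronger inhibitor), where compound 1 gives 400 nM. Compound 2 `CCOC(=O)C(=O)C(CC)NC(=O)C(CC(C)C)NC(=O)C(c1ccccc1)c1ccccc1` gives 200 nM in this assay, a number within the scatter of compound 1. Compound 3 `CCOC(=O)C(=O)C(CC)NC(=O)C(CC(C)C)NC(=O)OCC(C)C` gives 17000 nM, a number well beyond the scatter above both compound 1 and compound 2, so compound 1 sits among the lower numbers of this small set, with only compound 3 clearly apart from it.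

Compound 4 `CCCCCCCNC(=O)C(=O)C(CC)NC(=O)C(CC(C)C)NC(=O)OCc1ccccc1` is not yet measured. It differs from compound 1 in one place: heptylamino in place of butoxy on a carbonyl carbon. Cut one bond further out, the change reads butoxycarbonyl to heptylcarbamoyl.

Within the data shown here, no measured pair in this set shows this change, so the size of the step rests on expectation alone. The expected step from compound 1 to compound 4 in this assay is a 3.3-fold lower number from compound 1 to compound 4 (0.52 log units; beyond the scatter), a modest move towards a lower number, possibly not beyond the scatter. Compound 4 is therefore estimated at 120 nM, with a range from 25 nM to 600 nM.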

Compound 4, inhibition constant: 67 nM
Compound 4: the middle estimate sits 1.8-fold (0.25 log units) above what was measured, and the stated range covers the measured number.
By their numbers in this assay, from the lowest: compound 4; then compounds 2 and 1 (each within the scatter of the next); then compound 3.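

Within the data shown here, the step of a 6.0-fold lower number from compound 1 to compound 4 (0.78 log units; beyond the scatter) in this assay is the first comparison that differs in one place, and it shows that the carbonyl carbon tolerates a change from ketoester to ketoamide without loss of inhibition. Heptylamino brings a hydrogen-bond donor and a longer chain to this position in a single change, and the number still falls beyond the scatter. Nothing on hand explains why the number falls.

The one step changes both the linking atom and the chain, so the compounds shown cannot separate the two; butylamino and heptyloxy on the same core would divide them. Also open, from the compounds shown here alone, is whether the same change holds with the other groups of compound 2 and compound 3, and how a shorter amine or a terminal carboxylic acid on the chain would read.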